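The compounds below may be only part of what the source reports. "The series", "measured", "known", "first", "only" and "open" are said of these compounds alone.

Measured compounds:
compound 1, `CN(C)C(=O)c1cc2cnc(Nc3ccc(S(=O)(=O)NCCCCCN=C=S)cc3)nc2n1C1CCCC1`, 83.4%
compound 2, `CN(C)C(=O)c1cc2cnc(Nc3ccc(C(=O)NCCCN=C=S)cc3)nc2n1C1CCCC1`, 91.2%

Both compounds share the same core and were tested in a functional assay on NCI-H1299 cells (Homo sapiens) for inhibition, read by CCK-8 assay, with a stated time of 72 h, tested at 10 uM; on this read-out lower numbers stand for a weaker effect and higher numbers for a stronger effect at the one concentration tested. Compound 2 has the highest of the two numbers, and its nearest neighbour is compound 1, whose value differs by a step that is within the scatter of the assay, so the two cannot be ranked against each other.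

Compound 3, `CN(C)C(=O)c1cc2cnc(Nc3ccc(C(=O)NCCCCCN=C=S)cc3)nc2n1C1CCCC1`, has not yet been measured. It differs from compound 2 by a group of 5 heavy atoms (3 carbon, 1 nitrogen, 1 sulfur; no ring) in place of a group of 3 heavy atoms (1 carbon, 1 nitrogen, 1 sulfur; no ring), on a saturated chain carbon, three bonds along the chain from an amide-type nitrogen. Among the measured compounds shown here, the only measured step, a number 7.8 percentage points higher from compound 1 to compound 2 (within the scatter), swaps one chain-bearing group for another at the aromatic carbon and falls within the scatter. That step is the closest guide, since it also changes the length of the chain that ends in the isothiocyanate, although it alters more than the chain alone. On this basis no step beyond the scatter is expected in this assay from compound 2 to compound 3, in either direction. Compound 3 is therefore estimated at 89%, with a plausible range from 78% to 96%, which means an expected step of a number 2.2 percentage points lower from compound 2 to compound 3 (within the scatter).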

Compound 3, a percentage reported as inhibition, at one concentration (the size of the read-out at that concentration, not a potency): 76.5%
The estimate for compound 3 lay 12.5 percentage points above the measured number; the measured number lies below the stated range.
By their numbers in this assay, from the lowest: compounds 3, 1 and 2 (each within the scatter of the next, the first and the last beyond it).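

Within the amide series, the longer chain ending in the isothiocyanate gives a number 14.7 percentage points lower from compound 2 to compound 3 (beyond the scatter) in this assay, so the length of this chain can matter at this position. Compound 2 and compound 3 differ only in that chain, whereas the earlier pair changed the linking group and the chain together and could not show this. With the chain length held the same, the change from the sulfonamide of compound 1 to the amide of compound 3 gives a number 6.9 percentage points lower from compound 1 to compound 3 (within the scatter), so at this length the two linking groups cannot be told apart in this read-out. No supporting data are available to explain the effect of the longer chain.

Two chain lengths on the amide define no trend, so a chain of four carbons between them or a longer chain of six carbons could show whether the number falls steadily or changes abruptly. The compounds shown also leave open whether the isothiocyanate is needed for the effect, which a chain ending in an amine or an acetamide in its place would test.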